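Alkynyl hydrazone sulfonamides: notes toward compound 4

The source may hold more compounds than are shown below. What is called first, only, known or untested is meant among the compounds shown, and "the series" means these compounds.

The three measured compounds were all run in a functional assay on HCT-116 cells (Homo sapiens) for antiproliferative activity, read by MTT assay, with a stated time of 72 h; on this read-out higher numbers stand for weaker inhibition and lower numbers for stronger inhibition.

compound 1, `Cc1cc(S(=O)(=O)/N=C(\N)N/N=C/C#Cc2ccccc2)c(SCc2ccc(Cl)cc2)cc1Cl`: compound 1 gives 8000 nM
compound 2, `C/C(C#Cc1ccccc1)=N\N/C(N)=N/S(=O)(=O)c1cc(C)c(Cl)cc1SCc1ccc(Cl)cc1`: compound 2 gives 10000 nM
compound 3, `Cc1cc(S(=O)(=O)/N=C(\N)N/N=C/C#Cc2ccccc2)c(SCc2cccc3ccccc23)cc1Cl`: compound 3 gives 10000 nM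

Compound 3 differs from compound 1 in the core, namely (naphthalen-1-yl in place of 4-chlorophenyl on a saturated chain carbon bound to a sulfur). The step that goes with this is a 1.3-fold higher number from compound 1 to compound 3 (0.10 log units; within the scatter). Compound 2 differs from compound 1 by a group of 11 heavy atoms (10 carbon, 1 nitrogen; one six-membered aromatic ring of carbon only) in place of a group of 10 heavy atoms (9 carbon, 1 nitrogen; one six-membered aromatic ring of carbon only), on an amine nitrogen, and that step is a 1.3-fold higher number from compound 1 to compound 2 (0.10 log units; within the scatter). Compound 2 and compound 3 stand level at the digits given, so no order between them can be read.

Compound 4, `C/C(C#Cc1ccccc1)=N\N/C(N)=N/S(=O)(=O)c1cc(C)c(Cl)cc1SCc1cccc2ccccc12`, has not yet been measured. It differs from compound 3 by a group of 11 heavy atoms (10 carbon, 1 nitrogen; one six-membered aromatic ring of carbon only) in place of a group of 10 heavy atoms (9 carbon, 1 nitrogen; one six-membered aromatic ring of carbon only), on an amine nitrogen. This is the same change as that from compound 1 to compound 2: the group that leaves and the group that enters are the same, and the place, an amine nitrogen whose other neighbours are a carbon with a double bond to nitrogen, is described in identical words for both pairs. What sets the two pairs apart is only the core, as told under the difference between compound 1 and compound 3.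

The step from compound 3 to compound 4 in this assay is expected to be a 1.2-fold higher number from compound 3 to compound 4 (0.08 log units; within the scatter), next to the earlier step of a 1.3-fold higher number from compound 1 to compound 2 (0.10 log units; within the scatter). This expectation rests on a single measured instance of the change, so it carries little weight; because the step of a 1.3-fold higher number from compound 1 to compound 2 (0.10 log units; within the scatter) stayed within the scatter, a step of similar small size is expected here. Compound 4 is therefore estimated at 12000 nM, with a range from 6000 nM to 25000 nM expected.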

Compound 4, half-maximal inhibitory concentration: 105000 nM
Estimate against measurement, compound 4: 8.8-fold (0.94 log units) below, outside the stated range (above it).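

In this assay the exchange on the amine nitrogen does not carry from the core of compound 1 to the core of compound 3, with an 11-fold higher number from compound 3 to compound 4 (1.02 log units; beyond the scatter) against a step within the scatter on the first core: the same change on two cores in this assay, a 1.3-fold higher number (0.10 log units; within the scatter) from compound 1 to compound 2 and an 11-fold higher number (1.02 log units; beyond the scatter) from compound 3 to compound 4, 8.4-fold (0.92 log units) apart, beyond the scatter of two such steps

Naphthalen-1-yl in place of 4-chlorophenyl on a saturated chain carbon bound to a sulfur behaves the same way, with an 11-fold higher number from compound 2 to compound 4 (1.02 log units; beyond the scatter) against a step within the scatter when the first group stays on the amine nitrogen: the same change on two cores in this assay, a 1.3-fold higher number (0.10 log units; within the scatter) from compound 1 to compound 3 and an 11-fold higher number (1.02 log units; beyond the scatter) from compound 2 to compound 4, 8.4-fold (0.92 log units) apart, beyond the scatter of two such steps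

The two changes therefore do not add up as separate steps in these four compounds: each alone stays within the scatter, and only compound 4, which carries both, stands apart, with weaker inhibition; this shows a dependence of one change on the other within this single set of four compounds and one read-out, but it does not show what lies behind that dependence or that it extends to any other pair of groups.

Open, as far as these compounds go, is whether the same gap appears with a cyclohexyl or a 4-methoxyphenyl group on the saturated chain carbon bound to a sulfur, or whether it belongs to naphthalen-1-yl alone. Also open, from the compounds shown here alone, is how an ethyl group in place of the added carbon in the group on the amine nitrogen would behave on either core.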